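The compounds below may be only part of what the source reports. "The series", "measured", "known", "first", "only" and "open" are said of these compounds alone.

Compound 1 `O=C(O)CC1COc2cc(OCc3ccc(C(=O)N4CCN(c5ccc(F)cc5)CC4)s3)ccc21`: > 1660 nM in a functional assay on HEK293 cells for agonist activity at Free fatty acid receptor 1 (Homo sapiens), read by fluorescence and calcium flux; a higher number here means that more compound is needed for the effect, a lower number that less compound is needed.
Compound 2 `CC#CC(CC(=O)O)c1ccc(OCc2cnc(C(=O)N3CCc4ccccc4C3)s2)cc1`: 531 nM in this assay.

The value given for compound 1 is a limit of the assay, not a number. Compound 2 therefore holds the only actual number shown, the other entry being a limit, as the limit of > 1660 nM in this assay, at which 1 of the 2 values shown sits, records. Compound 3 `CC#CC(CC(=O)O)c1ccc(OCc2cnc(C(=O)NC3CCCc4ccccc43)s2)cc1` differs from compound 2 in one place: (1,2,3,4-tetrahydronaphthalen-1-yl)amino in place of 1,2,3,4-tetrahydroisoquinolin-2-yl on a carbonyl carbon. Within the data shown here, no measured pair shows a change of this kind, so the step expected here is a 1.4-fold higher number from compound 2 to compound 3 (0.15 log units; within the scatter), a change that is not expected to reach beyond the usual scatter. Compound 3 is estimated at 750 nM in this assay, somewhere between 250 nM and 2500 nM.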

Compound 3, half-maximal effective concentration: 144 nM
Compound 3: the middle estimate sits 5.2-fold (0.72 log units) above what was measured; the whole stated range lies above it.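

Putting (1,2,3,4-tetrahydronaphthalen-1-yl)amino in place of 1,2,3,4-tetrahydroisoquinolin-2-yl on the carbonyl carbon gives a 3.7-fold lower number from compound 2 to compound 3 (0.57 log units; beyond the scatter) in this assay. Among these compounds, this is the first measured sign that the group at this place matters, and the entering group carries a hydrogen-bond donor that the leaving group lacks. Nothing measured here explains the gain.

The compounds shown leave open whether the amide hydrogen or the all-carbon ring goes with the lower number. A simple benzylamino group or a methyl on the amide nitrogen at this place would be untested ground among them.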